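The source may hold more compounds than are shown below. What is called first, only, known or untested is meant among the compounds shown, and "the series" means these compounds.

All three measured compounds share one core. Compound 1 `Cc1c(-c2ccccc2)sc(N)c1C(=O)c1ccc(Cl)cc1` gives 1% in an assay on CHO cells for displacement of a labelled ligand from adenosine receptor A1 (Homo sapiens), read by scintillation counting, tested at 10 uM (a higher number here means more inhibition at the concentration tested (going by the name of the read-out), a lower number less inhibition), compound 2 `COc1ccc(-c2sc(N)c(C(=O)c3ccc(Cl)cc3)c2C)cc1` gives 1%, and compound 3 `CC(C)(C)Cc1c(-c2ccncc2)sc(N)c1C(=O)c1ccc(Cl)cc1` gives 1%. For the measured compounds named here, the only single-change comparison among them, no change at the digits printed from compound 1 to compound 2 (within the scatter), shows that placing a methoxy in place of hydrogen on an aromatic carbon left the result where it was. Compound 3 therefore stands level with compounds 1 and 2, with nothing here rising out of the scatter.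

Compound 4 `CC(C)(C)Cc1c(-c2ccc(Cl)c(Cl)c2)sc(N)c1C(=O)c1ccc(Cl)cc1` differs from compound 3 in one place: 3,4-dichlorophenyl in place of pyridin-4-yl on an aromatic carbon. Going by the values given here, no measured pair tests an exchange of this aryl group, so the only guide is the flat picture so far, in which the step from compound 1 to compound 2 and the position of compound 3 show no movement at all. On that basis the step from compound 3 to compound 4 is expected to be a number 2 percentage points higher from compound 3 to compound 4 (within the scatter), that is, none beyond the scatter. Compound 4 is estimated at 3%, within a range from -8% to 15%.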

Compound 4, a percentage reported as inhibition, at one concentration (the size of the read-out at that concentration, not a potency): 1%
Compound 4: the middle estimate sits 2 percentage points above what was measured, within the range that was stated.
By their numbers in this assay, from the lowest: compounds 1, 2, 3 and 4 (each within the scatter of the next).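

In this assay, the exchange at the aromatic carbon next to the ring sulfur gives no change at the digits printed from compound 3 to compound 4 (within the scatter) when 3,4-dichlorophenyl enters in place of pyridin-4-yl. The earlier single-change pair only added a methoxy to an aryl ring, whereas here the whole ring is exchanged: a ring with one nitrogen and one hydrogen-bond acceptor leaves, and a carbon-only ring with two chlorines and no acceptor enters, yet the read-out does not move. Nothing available explains this lack of movement.

As far as these compounds go, whether a carboxylic acid or a piperazine on this aryl ring would lift the number remains open. So does the effect of a longer chain in place of the neopentyl group, or of an amide at the amino group.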